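This account rests on a few compounds, and the source may have more. Where it says the series, first, only, none or still open, it means among the compounds named here.

Compound 1 `O=C(N/N=C/c1cccc([N+](=O)[O-])c1)N1CCc2ncnc(Nc3ccc(F)c(Cl)c3)c2C1` gives 86900 nM
Compound 2 `Cc1ccc(/C=N/NC(=O)N2CCc3ncnc(Nc4ccc(F)c(Cl)c4)c3C2)cc1C` gives 6830 nM
Compound 3 `N#Cc1ccc(/C=N/NC(=O)N2CCc3ncnc(Nc4ccc(F)c(Cl)c4)c3C2)cc1` gives 67500 nM

All three numbers come from a functional assay on NCI-H1975 cells (Homo sapiens) for cytotoxicity, read by MTT assay, with a stated time of 72 h; on this read-out higher numbers stand for weaker inhibition and lower numbers for stronger inhibition. Compound 1 sits at the weak end of this small set. One step from it stays within the scatter (a 1.3-fold lower number from compound 1 to compound 3 (0.11 log units; within the scatter)), while the other is large (a 13-fold lower number from compound 1 to compound 2 (1.10 log units; beyond the scatter)).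

The next compound to consider is compound 4 `O=C(N/N=C/c1cccs1)N1CCc2ncnc(Nc3ccc(F)c(Cl)c3)c2C1`. It keeps the core of compound 1 and has thiophen-2-yl in place of 3-nitrophenyl on a carbon with a double bond to nitrogen.

Both measured steps from compound 1 change the group at this same place, so both bear on the new change, although neither brings in a five-membered ring. The group in compound 4 has no nitro or nitrile group, and the same is true of the 3,4-dimethylphenyl group in compound 2. That resemblance is only a rough guide, but compound 2 does stand apart from the nitrile-bearing compound 3 (a 9.9-fold higher number from compound 2 to compound 3 (0.99 log units; beyond the scatter)).

A drop in the number is therefore expected, though a smaller one than the large step to compound 2. The expected change is this (a 4.0-fold lower number from compound 1 to compound 4 (0.60 log units; beyond the scatter)). The estimate for compound 4 is 22000 nM (expected range 5000 nM to 85000 nM).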

Compound 4, half-maximal inhibitory concentration: 33000 nM
For compound 4 the middle estimate is 1.5-fold (0.18 log units) below the measured one, within the range that was stated.
By their numbers in this assay, from the lowest: compound 2; then compound 4; then compounds 3 and 1 (each within the scatter of the next).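

In this assay, a five-membered aromatic ring holding sulfur can stand on the carbon with a double bond to nitrogen, and it gives a change beyond the scatter (a 2.6-fold lower number from compound 1 to compound 4 (0.42 log units; beyond the scatter)). Compound 1 and compound 3 lay within the scatter of each other, but thiophen-2-yl separates from the 4-cyanophenyl group as well (a 2.0-fold lower number from compound 3 to compound 4 (0.31 log units; beyond the scatter)), while it still falls short of 3,4-dimethylphenyl (a 4.8-fold higher number from compound 2 to compound 4 (0.68 log units; beyond the scatter)), so this position now shows three levels rather than two. No measurement of any other kind accompanies these numbers, so the order stays unexplained.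

Compound 4 changes ring size, brings in sulfur and loses the nitro group all at once, and these three changes cannot be told apart from the compounds shown. A plain phenyl ring would help to separate them, as would a furan-2-yl ring, which keeps the five-membered ring with oxygen in place of sulfur, and a phenyl ring carrying a dimethylamino group would test a kind of substituent absent from this set.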